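This account rests on a few compounds, and the source may have more. Where it says the series, first, only, none or still open, it means among the compounds named here.

Notes on the series. Compound 2 `Cn1cnnc1SCC(=O)N/N=c1/scc(-c2ccccc2)n1-c1ccccc1` and compound 1 `Cn1nnnc1SCC(=O)N/N=c1/scc(-c2ccc(C#N)cc2)n1-c1ccccc1` have each been measured in a functional assay on C6 cells (Rattus norvegicus) for cytotoxicity, read by MTT assay, with a stated time of 24 h, tested at 100 ug/mL; a higher number here means a weaker effect of the compound at the concentration tested, a lower number a stronger effect. In this assay compound 2 gives 38.6%, and compound 1 gives 30.9%; compound 2 stands highest of the two numbers, but its gap to compound 1 lies within the scatter, so the two cannot be told apart on these data. Among the compounds with values here, no pair of measured compounds differs in only one place, so no single-change step is available.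

Compound 3 `Cn1nnnc1SCC(=O)N/N=c1/scc(-c2ccccc2)n1-c1ccccc1` remains to be measured in this assay. It differs from compound 2 in one place: 1-methyl-1H-tetrazol-5-yl in place of 4-methyl-4H-1,2,4-triazol-3-yl on a sulfur. A step no larger than the scatter is expected, if anything slightly downward, because compound 1, which also carries the 1-methyl-1H-tetrazol-5-yl group on its sulfur, gives 30.9%. The step from compound 2 to compound 3 is estimated at a number 4.6 percentage points lower from compound 2 to compound 3 (within the scatter). Compound 3 is accordingly expected to give 34% in this assay, with a range from 22% to 46%.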

Compound 3, a percentage reported as activity, at one concentration (the size of the read-out at that concentration, not a potency): 38.8%
Estimate against measurement, compound 3: 4.8 percentage points below, within the range that was stated.
By their numbers in this assay, from the lowest: compounds 1, 2 and 3 (each within the scatter of the next).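

In this assay, within the data shown here, the first single-change step, 1-methyl-1H-tetrazol-5-yl in place of 4-methyl-4H-1,2,4-triazol-3-yl on a sulfur, reads as a number 0.2 percentage points higher from compound 2 to compound 3 (within the scatter) and so does not separate these two groups at this position, with the phenyl group of compound 3 held the same as in compound 2. The second step, hydrogen in place of cyano on an aromatic carbon, reads as a number 7.9 percentage points higher from compound 1 to compound 3 (within the scatter) and leaves cyano and hydrogen equally unseparated at that place while 1-methyl-1H-tetrazol-5-yl stays on the sulfur. Nothing measured here speaks to the reason for either result.

Neither step reaches beyond the scatter, so the compounds shown do not tell whether the number responds at all to changes at these two places, for instance to a carboxylic acid or an amine in place of the five-membered aromatic ring on the sulfur. They also leave open whether the cyano-to-hydrogen result would hold with 4-methyl-4H-1,2,4-triazol-3-yl on the sulfur.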